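The compounds below may be only part of what the source reports. "The series", "measured", "known", "first", "only" and "open" are said of these compounds alone.

Compound 1 `CC1(C)S[C@@H]2/C(=C\C(=O)c3ccco3)C(=O)N2[C@H]1C(=O)OC(c1ccccc1)c1ccccc1`: 26000 nM
Compound 2 `CC1(C)[C@H](C(=O)OC(c2ccccc2)c2ccccc2)N2C(=O)/C(=C/C(=O)c3ccc([N+](=O)[O-])cc3)[C@H]2S1(=O)=O`: 76700 nM

Of the compounds shown here, two have been measured in a functional assay on A-375 cells (Homo sapiens) for cytotoxicity, read by MTT assay, with a stated time of 48 h; a lower number here means a stronger inhibitor, a higher number a weaker inhibitor. Compound 1 gives 26000 nM, while compound 2 gives 76700 nM. Compound 1 therefore stands lowest of the two numbers, and its gap to compound 2 is beyond the usual scatter, so compound 1 is the stronger of the pair, although both are weak inhibitors on this scale.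

Compound 3 `CC1(C)S[C@@H]2/C(=C\C(=O)OCc3ccccc3)C(=O)N2[C@H]1C(=O)OC(c1ccccc1)c1ccccc1` has not yet been measured. It differs from compound 1 in a single place: benzyloxy in place of furan-2-yl on a carbonyl carbon. Going by the values given here, no pair of measured compounds shows a change of this kind, so there is no measured step to lean on here, and the change keeps the same count of hydrogen-bond donors and acceptors. The step is expected to be a 1.3-fold higher number from compound 1 to compound 3 (0.13 log units; within the scatter), small and within the scatter, with no clear direction. Compound 3 is estimated at 35000 nM, with a range from 12000 nM to 100000 nM.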

Compound 3, half-maximal inhibitory concentration: 7100 nM
For compound 3 the middle estimate is 4.9-fold (0.69 log units) above the measured one, and the stated range ends above it.
By their numbers in this assay, from the lowest: compound 3; then compound 1; then compound 2.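

In this assay, going by these compounds alone, benzyloxy in place of furan-2-yl on a carbonyl carbon gives a 3.7-fold lower number from compound 1 to compound 3 (0.56 log units; beyond the scatter) and so goes beyond the scatter, the first sign that the group at this position matters for the number. The change replaces a five-membered aromatic ring with one hetero atom by a six-membered aromatic ring of carbon only, while the counts of hydrogen-bond donors and acceptors stay the same, so those counts alone do not account for the shift. Nothing available explains why the number falls.

This single step cannot show whether the lower number comes from the benzene ring or from the oxygen and carbon that link it to the carbonyl. A methoxy group, or a phenyl group joined directly to this carbonyl carbon, would help separate those two parts.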